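From anilino to (4-chlorophenyl)amino in compound 1

The source may hold more compounds than are shown below. What is called first, only, known or untested is meant among the compounds shown, and "the series" means these compounds.

Among the measured compounds shown here, in a functional assay on MOLT-4 cells (Homo sapiens) for antiproliferative activity, read by cell counting, with a stated time of 2 days (a lower number here means a stronger inhibitor, a higher number a weaker inhibitor), compound 1 `COc1cc(C(=O)c2sc(Nc3ccccc3)nc2N)cc(OC)c1OC` gives 6 nM, the lower of the two numbers known, and compound 2 `COc1ccc(Nc2nc(N)c(C(=O)c3ccc(Br)cc3)s2)cc1` gives 16 nM, a gap beyond the scatter. Compound 3 `COc1cc(C(=O)c2sc(Nc3ccc(Cl)cc3)nc2N)cc(OC)c1OC` has not yet been measured. It carries chloro in place of hydrogen on an aromatic carbon of compound 1, para to a large group (chloro in place of hydrogen on an aromatic carbon). For the measured compounds named here, no measured pair shows this change, so only a small rise in the number, near the edge of the scatter, is expected in this assay. The expected step is a 2.0-fold higher number from compound 1 to compound 3 (0.30 log units; within the scatter). For compound 3 the estimated value is 12 nM, with an expected range of 3 nM to 50 nM.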

Compound 3, half-maximal inhibitory concentration: 110 nM
Beside the measured number, compound 3's estimate is 9.2-fold (0.96 log units) below it, outside the stated range (above it).
By their numbers in this assay, from the lowest: compound 1; then compound 2; then compound 3.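

In this assay the phenyl of compound 1 does not tolerate this change freely: chloro in place of hydrogen, para to a large group, gives an 18-fold higher number from compound 1 to compound 3 (1.26 log units; beyond the scatter) from a single added heavy atom. Among the compounds shown here, this is the first step that can be read at this position, since compound 1 and compound 2 differ in more than one place. Nothing at hand explains the size of this loss.

Going by these compounds, whether fluoro, methyl or an amine at this place would cost as much remains open. So does whether the same step would hold on a different core.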